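Adding fluoro to compound 3 at the assay limit

This account rests on a few compounds, and the source may have more. Where it says the series, first, only, none or still open, it means among the compounds named here.

Measured so far in an ADME assay on RAW264.7 cells (Mus musculus) for cytotoxicity, read by MTT assay, with a stated time of 24 h, in the absence of a further agent; on this read-out lower numbers stand for stronger inhibition and higher numbers for weaker inhibition (each value is a limit, not a number):
Compound 1 (`COc1ccc(C(O)C2OC(=O)c3c(OC)cc(OC)cc32)cc1`): > 40000 nM
Compound 2 (`COCCCCOc1ccc(C(O)C2OC(=O)c3c(OC)cc(OC)cc32)cc1`): > 40000 nM
Compound 3 (`COc1cc(OC)c2c(c1)C(C(O)c1ccc(OCc3ccccc3)cc1)OC2=O`): > 40000 nM

Compound 3 gives > 40000 nM, which is a limit and not a number. It has no readable place in the series, which shows the limit of > 40000 nM in this assay, at which 3 of the 3 values shown sit, for its whole set of values.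

Compound 4 (`COc1cc(OC)c2c(c1)C(C(O)c1ccc(OCc3ccc(F)cc3)cc1)OC2=O`) carries fluoro in place of hydrogen on an aromatic carbon, para to a large group, so that benzyloxy becomes (4-fluorobenzyl)oxy: fluoro in place of hydrogen on an aromatic carbon.

The measured steps that bear on this all alter the group on the oxygen. They are a step that the two limits leave unreadable from compound 1 to compound 3, a step that the two limits leave unreadable from compound 2 to compound 3 and a step that the two limits leave unreadable from compound 1 to compound 2. None has a readable size and none introduces fluoro, so they offer no sign of movement in this assay.

The expected size is a step that the limit leaves unreadable from compound 3 to compound 4, and no change beyond the scatter is expected in either direction. Compound 4 is estimated at 50000 nM, with an expected range from 25000 nM to 100000 nM.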

Compound 4, half-maximal inhibitory concentration: > 40000 nM
Compound 4 ended at the assay's limit; the forecaster's own chance of this, stated with the estimate: 85%; the middle value does not contradict the limit.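

In this assay compound 4 gives > 40000 nM, which is a limit and not a number. Within the data shown here, no step from compound 1, compound 2 or compound 3 to compound 4 can be read: the limit of > 40000 nM in this assay, at which 4 of the 4 values shown sit. The compounds shown leave open whether fluoro changes cytotoxicity at all in this assay.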